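This account rests on a few compounds, and the source may have more. Where it says the series, first, only, none or still open, it means among the compounds named here.

Measured compounds:
Compound 1, `Cc1cc(C(=O)O)ccc1OCCCCOc1ccc(C(=O)CC(C)C)c(O)c1C`, gives 83.9%.
Compound 2, `Cc1cc(OCCCCOc2ccc(C(=O)CC(C)C)c(O)c2C)ccc1C(=O)O`, gives 93.3%.
Compound 3, `Cc1cc(C(=O)O)ccc1OCCCCOc1ccc(C(=O)CC2CCCC2)c(O)c1C`, gives 84.6%.

All three were tested in an assay on HEK293 cells for positive allosteric modulation of metabotropic glutamate receptor 2 (Rattus norvegicus), read by thallium flux, with a stated time of 2.5 min; on this read-out higher numbers stand for larger maximal responses and lower numbers for smaller maximal responses. Compound 1 and compound 2 share everything except the aromatic acid at one end of the chain: the difference is 4-carboxy-3-methylphenyl in place of 4-carboxy-2-methylphenyl on an oxygen on a saturated carbon. This change gives a number 9.4 percentage points higher from compound 1 to compound 2 (within the scatter), so the two values cannot be told apart by this measurement.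

Compound 3 differs from compound 1 at the other end of the molecule, where the group beside the carbonyl is changed: cyclopentyl in place of isopropyl on a saturated chain carbon bound to a carbonyl carbon. That step is a number 0.7 percentage points higher from compound 1 to compound 3 (within the scatter), again a difference that the measurement cannot resolve.

Compound 4, `Cc1cc(OCCCCOc2ccc(C(=O)CC3CCCC3)c(O)c2C)ccc1C(=O)O`, has not yet been measured in this assay. It is related to compound 3 by 4-carboxy-3-methylphenyl in place of 4-carboxy-2-methylphenyl on an oxygen on a saturated carbon, which is the same change, at the same place, that turns compound 1 into compound 2. Going by the values given here, the only earlier example of this change, from compound 1 to compound 2, stayed within the scatter of the assay, and the core of compound 3 and the core of compound 1 gave nearly identical numbers, so there is no sign that the change acts differently on either core.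

Among the compounds with values here, the step from compound 3 to compound 4 is therefore expected to be small, about a number 6.4 percentage points higher from compound 3 to compound 4 (within the scatter), resting on the single earlier step of a number 9.4 percentage points higher from compound 1 to compound 2 (within the scatter). Compound 4 is estimated to give 91% in this assay, with a likely range from 81% to 100%, and a measured number rather than a limit is expected.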

Compound 4, largest response reached (reported as percent of maximum), in percent of the reference or control that the assay uses: 83.6%
Compound 4: middle estimate off by 7.4 percentage points, on the high side; the measured number falls inside the stated range.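

On the core of compound 3, 4-carboxy-3-methylphenyl in place of 4-carboxy-2-methylphenyl gives a number 1 percentage points lower from compound 3 to compound 4 (within the scatter), and the two examples of this change in this assay cannot be told apart: the same change on two cores in this assay, a number 9.4 percentage points higher (within the scatter) from compound 1 to compound 2 and a number 1 percentage points lower (within the scatter) from compound 3 to compound 4, 10.4 percentage points apart, within the scatter of two such steps. The second change in the set, cyclopentyl in place of isopropyl, gives a number 9.7 percentage points lower from compound 2 to compound 4 (within the scatter), and its two examples cannot be told apart either: the same change on two cores in this assay, a number 0.7 percentage points higher (within the scatter) from compound 1 to compound 3 and a number 9.7 percentage points lower (within the scatter) from compound 2 to compound 4, 10.4 percentage points apart, within the scatter of two such steps. This shows that neither change, on the two cores tested, produced a step that this measurement can resolve, but it does not show that either change carries over with the same size, since every step here lies within the scatter and a real dependence on the core could be hidden inside it.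

On these data alone, the four compounds vary only the position of one methyl group and the choice of isopropyl or cyclopentyl, so it remains open whether a change with a clearly measurable step would transfer from one core to another. Also open, as far as these compounds go, is how the maximal response would respond to larger edits, such as a tetrazole in place of the carboxylic acid, a chlorine in place of the methyl group, or a longer chain linking the two aromatic rings.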